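The source may report more compounds than this note shows. Statements on the series, on what has been measured and on what is new or still open speak of the compounds shown alone.

Compound 1 `C/N=C(/NC#N)NCCCCCn1nc(-c2ccccc2)ccc1=O` carries a phenyl on the shared core, and in a functional assay on the whole organism with Rattus norvegicus as the target, at a dose of 100 mg/kg (a higher number here means more inhibition at the dose given (going by the name of the read-out), a lower number less inhibition), compound 1 gives 47.6%. Compound 2 `C/N=C(/NC#N)NCCCCCn1nc(C)ccc1=O` differs from it in one place, (methyl in place of phenyl on an aromatic carbon), and in this assay compound 2 gives 14.9%. That single change made a step of a number 32.7 percentage points lower from compound 1 to compound 2 (beyond the scatter).

Compound 3 `CCC/N=C(/NC#N)NCCCn1nc(-c2ccccc2)ccc1=O` has the same atoms as compound 1 joined differently; the difference between the two cores is not broken down here. In this assay compound 3 gives 52.9%, and the two values of compound 3 and compound 1 lie within the usual scatter of each other.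

Compound 4 `CCC/N=C(/NC#N)NCCCn1nc(C)ccc1=O` has not yet been measured. It stands to compound 3 as compound 2 stands to compound 1, with the same change, (methyl in place of phenyl on an aromatic carbon), at the same place. Within the data shown here, since the only earlier example of this change is the step of a number 32.7 percentage points lower from compound 1 to compound 2 (beyond the scatter), a step of about the same size is expected from compound 3 to compound 4, namely a number 32.9 percentage points lower from compound 3 to compound 4 (beyond the scatter). On that basis compound 4 is estimated to give 20% in this assay, expected to fall between 5% and 36%.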

Compound 4, a percentage reported as inhibition, in the whole organism at one dose (the size of the read-out at that dose, not a potency): 17.5%
The estimate for compound 4 lay 2.5 percentage points above the measured number; low and high end bracket the measured number.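

Put in place of phenyl on the core of compound 3, methyl gave in this assay a step of a number 35.4 percentage points lower from compound 3 to compound 4 (beyond the scatter), and set beside the earlier case, the change carried over with much the same size: the same change on two cores in this assay, a number 32.7 percentage points lower (beyond the scatter) from compound 1 to compound 2 and a number 35.4 percentage points lower (beyond the scatter) from compound 3 to compound 4, 2.7 percentage points apart, within the scatter of two such steps. For these two cores, which hold the same atoms joined differently, a step read on one core therefore served as a fair guide to the step on the other. Among these compounds, this rests on only two matched pairs, tested in one whole-organism assay at one dose, so it sets no rule for other cores and does not explain why the change has this effect.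

The compounds shown leave open whether a group other than phenyl or methyl at this place, such as ethyl, methoxy, chlorine or an amine, would fall along the same line. They also leave open whether the phenyl-to-methyl step would keep its size on a core with a longer chain.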